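Working notes: chloro in place of methoxy

A few compounds are considered here, and "the series" means these few. Any claim that something is new, unique, unknown or untested is made for them only; others in the source may bear on it.

Measured in an ADME assay on HEK293 cells (Homo sapiens) for cytotoxicity; a lower number here means a stronger inhibitor, a higher number a weaker inhibitor:
- compound 1 `CCCCCCCCCCCCCCNC(=O)[C@H](CO)/N=C/c1ccc(OC)cc1` gives 81700 nM
- compound 2 `CCCCCCCCCCCCCCNC(=O)[C@H](CO)/N=C/c1ccccc1OC` gives 79200 nM

For the measured compounds named here, compound 2 stands level with its only measured neighbour: a 1.0-fold lower number from compound 1 to compound 2 (0.01 log units; within the scatter). Next is compound 3 `CCCCCCCCCCCCCCNC(=O)[C@H](CO)/N=C/c1ccccc1Cl`, with chloro in place of methoxy on an aromatic carbon, ortho to a large group. Going by the values given here, the one measured step moves the methoxy group and does not replace it, so it bears only indirectly. Among the compounds with values here, no measured step covers this exchange. With that single step inside the scatter, no shift beyond the scatter is expected in this assay. The expected change is a 1.1-fold lower number from compound 2 to compound 3 (0.04 log units; within the scatter). For compound 3 the estimated value is 72000 nM, with an expected range of 36000 nM to 130000 nM.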

Compound 3, half-maximal inhibitory concentration: 94900 nM
For compound 3 the middle estimate is 1.3-fold (0.12 log units) below the measured one; low and high end bracket the measured number.
By their numbers in this assay, from the lowest: compounds 2, 1 and 3 (each within the scatter of the next).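

In this assay, chloro in place of methoxy on an aromatic carbon, ortho to a large group, gives a 1.2-fold higher number from compound 2 to compound 3 (0.08 log units; within the scatter) and stays within the scatter, so replacing the group, and not only moving it, leaves the read-out level. The 2-chlorophenyl compared with the 4-methoxyphenyl gives a 1.2-fold higher number from compound 1 to compound 3 (0.07 log units; within the scatter) and also stays within the scatter, so all three compounds stand level. From the compounds shown here alone, whether an amine or a carboxylic acid at this position, or a longer chain on the amide, would move the number beyond the scatter remains open. No measured evidence on the cause of these level values is at hand.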